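Trimming a Methyl From the Side Chain

The compounds below may be only part of what the source reports. "The series", "measured", "known", "first", "only" and "open" are said of these compounds alone.

Of the compounds shown here, two have so far been tested in a functional assay on the whole organism (stomach) for inhibition, with Rattus norvegicus as the target, at a dose of 100 mg/kg by the intraduodenal route; on this read-out higher numbers stand for more inhibition at the one dose given (going by the name of the read-out) and lower numbers for less inhibition. Compound 1 `C/N=C(\S)CCn1nc(-c2ccccc2)ccc1=O` gives 68.2%, while compound 2 `C/N=C(\S)C(C)Cn1ncccc1=O` gives 50.2%, the lower of the two numbers, a gap that lies beyond the usual scatter. Compound 3 `C/N=C(\S)CCn1ncccc1=O` has not yet been measured. It differs from compound 2 in one place: hydrogen in place of methyl on a saturated chain carbon bound to a carbon with a double bond to nitrogen and a saturated chain carbon. Among the compounds with values here, no measured pair shows this change on its own, so its effect cannot be read from the numbers. The step expected here is a number 4.8 percentage points higher from compound 2 to compound 3 (within the scatter), small and within the scatter. Compound 3 is therefore estimated at 55%, with a likely range from 35% to 75% in this assay.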

Compound 3, a percentage reported as inhibition, in the whole organism at one dose (the size of the read-out at that dose, not a potency): 35.7%
Beside the measured number, compound 3's estimate is 19.3 percentage points above it, and the stated range covers the measured number.
By their numbers in this assay, from the lowest: compound 3; then compound 2; then compound 1.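

In this assay, hydrogen in place of methyl on the saturated chain carbon gives a number 14.5 percentage points lower from compound 2 to compound 3 (beyond the scatter) and so is not a neutral change at this position. Hydrogen in place of phenyl on an aromatic carbon gives a number 32.5 percentage points lower from compound 1 to compound 3 (beyond the scatter) and shows that the phenyl-bearing compound keeps far more inhibition at this dose. Nothing measured here explains either step.

As far as these compounds go, whether an ethyl group on that chain carbon would match the methyl remains open. So does whether a pyridyl ring or a methoxy group could stand in for the phenyl.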